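Terminal hydroxylation of the hexyl disulfide chain

The source may report more compounds than this note shows. Statements on the series, on what has been measured and on what is new or still open speak of the compounds shown alone.

Compound 3 `CCCCCCSS[C@H]1C[C@H](n2cc(C)c(=O)[nH]c2=O)O[C@@H]1CO` gives 27000 nM in a functional assay on MOLT-4 cells (Homo sapiens) for cytotoxicity; a higher number here means a weaker inhibitor, a lower number a stronger inhibitor. That is the lowest of the three numbers seen so far: compound 2 `Cc1cn([C@H]2C[C@H](SSC(Cl)(Cl)Cl)[C@@H](CO)O2)c(=O)[nH]c1=O` gives 55000 nM in this assay, and compound 1 `CSS[C@H]1C[C@H](n2ccc(N)nc2=O)O[C@@H]1CO` gives 149000 nM. Among the compounds with values here, the one measured step that touches the chain on sulfur, a 2.0-fold lower number from compound 2 to compound 3 (0.31 log units; beyond the scatter), is modest in size. Compound 4 `Cc1cn([C@H]2C[C@H](SSCCCCCCO)[C@@H](CO)O2)c(=O)[nH]c1=O` differs from compound 3 by hydroxy in place of hydrogen on a saturated chain carbon, six bonds along the chain from a sulfur. Within the data shown here, no measured pair shows what a hydroxy group at the chain end does, so the step to compound 4 is expected to stay within the scatter, a 1.3-fold higher number from compound 3 to compound 4 (0.11 log units; within the scatter). Compound 4 is therefore estimated at 35000 nM in this assay, within a range of 15000 nM to 90000 nM.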

Compound 4, half-maximal inhibitory concentration: 42000 nM
Estimate against measurement, compound 4: 1.2-fold (0.08 log units) below, within the range that was stated.
By their numbers in this assay, from the lowest: compounds 3, 4 and 2 (each within the scatter of the next, the first and the last beyond it); then compound 1.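

In this assay, within the data shown here, the step of a 1.6-fold higher number from compound 3 to compound 4 (0.19 log units; within the scatter) stays within the scatter, the first reading of hydroxy in place of hydrogen on a saturated chain carbon, six bonds along the chain from a sulfur. The step of a 1.3-fold lower number from compound 2 to compound 4 (0.12 log units; within the scatter) also stays within the scatter, whereas the step of a 2.0-fold lower number from compound 2 to compound 3 (0.31 log units; beyond the scatter) lies just beyond it. No measurement shown bears on why these steps have the sizes they do.

Open, as far as these compounds go, is whether an amine or a carboxylic acid in place of this hydroxy would read apart from compound 3 in this assay as well. From the compounds shown here alone, a longer chain ending in hydroxy also remains open.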